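Working notes: from compound 2 to compound 4

The source may hold more compounds than are shown below. What is called first, only, known or untested is meant among the compounds shown, and "the series" means these compounds.

Half-maximal inhibitory concentrations in a functional assay on MCF7 cells (Homo sapiens) for cytotoxicity, read by MTT assay, with a stated time of 72 h (a lower number here means a stronger inhibitor, a higher number a weaker inhibitor), stand below
- compound 1 `CCC(C)=C1C(=O)N(c2ccc(Cl)cc2)N(c2ccc(Cl)cc2)C1=O` gives 41600 nM
- compound 2 `O=C1C(=Cc2ccc(F)cc2)C(=O)N(c2ccc(Cl)cc2)N1c1ccc(Cl)cc1` gives 31400 nM
- compound 3 `COc1cc(C=C2C(=O)N(c3ccc(Cl)cc3)N(c3ccc(Cl)cc3)C2=O)cc(OC)c1OC` gives 16200 nM

Going by the values given here, compound 2 (31400 nM) lies within the scatter of both compound 1 and compound 3, and no step between measured compounds differing in one place is available. Compound 4 `COc1cccc(C=C2C(=O)N(c3ccc(Cl)cc3)N(c3ccc(Cl)cc3)C2=O)c1O` carries 2-hydroxy-3-methoxyphenyl in place of 4-fluorophenyl on a double-bonded chain carbon bound to a double-bonded ring carbon. The nearest guide is compound 3 (16200 nM), whose group at that place also bears methoxy. In this assay a small expected step towards a lower number, a 2.2-fold lower number from compound 2 to compound 4 (0.35 log units; beyond the scatter), would stay close to the scatter. The estimate for compound 4 is 14000 nM within an expected range (5000 nM to 35000 nM).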

Compound 4, half-maximal inhibitory concentration: 26700 nM
Estimate against measurement, compound 4: 1.9-fold (0.28 log units) below; low and high end bracket the measured number.
By their numbers in this assay, from the lowest: compounds 3, 4, 2 and 1 (each within the scatter of the next, the first and the last beyond it).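

In this assay, going by these compounds alone, the exchange of 4-fluorophenyl for 2-hydroxy-3-methoxyphenyl gives a 1.2-fold lower number from compound 2 to compound 4 (0.07 log units; within the scatter) and provides the first one-place comparison at this position. The two compounds stand within the scatter of each other, although the entering group carries a hydrogen-bond donor and hydrogen-bond acceptors that 4-fluorophenyl lacks. No measurement shown here accounts for this result.

As far as these compounds go, whether an amine or a carboxylic acid at this place would give a step beyond the scatter remains open. From the compounds shown here alone, the separate contributions of the hydroxy and methoxy groups of compound 4 also remain open.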